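The source may report more compounds than this note shows. Statements on the series, on what has been measured and on what is new or still open speak of the compounds shown alone.

Compound 1, `OCCOCn1cnc2c(O)ncnc21`: > 100 ug/mL.
Compound 2, `Nc1nc2c(nc(Cl)n2COCCO)c(=O)[nH]1`: > 400 ug/mL.

Both compounds were tested in a functional assay (Oryctolagus cuniculus) for inhibition; a lower number here means a stronger inhibitor, a higher number a weaker inhibitor. For compound 1 the result > 100 ug/mL is a limit of the assay and not a number, as the limit of > 100 ug/mL in this assay, at which 1 of the 2 values shown sits, records. For compound 2 the result > 400 ug/mL is likewise a limit and not a number, as the limit of > 400 ug/mL in this assay, at which 1 of the 2 values shown sits, records. For the measured compounds named here, compound 2 therefore stands only at a limit in this assay; no numeric potency is known for it, and no step between two measured compounds can be drawn from these two results.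

Compound 3, `Nc1nc2c(nc(O)n2COCCO)c(=O)[nH]1`, has not yet been measured. It differs from compound 2 in one place: hydroxy in place of chloro on an aromatic carbon. The chloro leaves and a hydroxy enters on an aromatic carbon of a five-membered aromatic ring with two nitrogen atoms, part of the fused core shared with compound 2.

With compound 2 sitting at the limit > 400 ug/mL, no step beyond the scatter is expected from this single exchange, and compound 3 is expected to remain at a limit as well. The expected step is a number no higher from compound 2 to compound 3 (the limit leaves the size open). For compound 3 the estimate in this assay is 400 ug/mL, with a range from 100 ug/mL to 1000 ug/mL.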

Compound 3, concentration for 50% inhibition: >= 100 ug/mL
Compound 3 ended at the assay's limit; the forecaster's own chance of this, stated with the estimate: 85%; the middle value does not contradict the limit.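

In this assay compound 2 gives > 400 ug/mL, which is a limit of the assay and not a number. Compound 3 gives >= 100 ug/mL, also a limit, so no step can be read between compound 2 and compound 3. Left open is how strongly either compound inhibits, and whether hydroxy in place of chloro changes that at all.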